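Pyridyl Swap on the Oxadiazole Arm of Compound 3

A few compounds are considered here, and "the series" means these few. Any claim that something is new, unique, unknown or untested is made for them only; others in the source may bear on it.

Three compounds built on one shared core were measured in a functional assay on the whole organism (plasma, strain Wistar) with Rattus norvegicus as the target, with a stated time of 15 days, at a dose of 10 mg/kg by the oral route; a lower number here means a weaker effect, a higher number a stronger effect of the compound at the dose given. Compound 1 `O=C1NC(=O)/C(=C/c2ccc(OCCSc3nnc(-c4ccccc4)o3)cc2)S1` gives 14.6%, compound 2 `O=C1NC(=O)/C(=C/c2ccc(OCCSc3nnc(Cc4ccccc4)o3)cc2)S1` gives 16.8%, and compound 3 `O=C1NC(=O)/C(=C/c2ccc(OCCSc3nnc(-c4cccnc4)o3)cc2)S1` gives 33.2%. Compound 3 stands highest of the three: the step of a number 18.6 percentage points higher from compound 1 to compound 3 (beyond the scatter) and the step of a number 16.4 percentage points higher from compound 2 to compound 3 (beyond the scatter) are both beyond the scatter, whereas a number 2.2 percentage points higher from compound 1 to compound 2 (within the scatter) lies within it, so compounds 1 and 2 cannot be ordered against each other.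

Compound 4 `O=C1NC(=O)/C(=C/c2ccc(OCCSc3nnc(-c4ccncc4)o3)cc2)S1` has not yet been measured. It differs from compound 3 by pyridin-4-yl in place of pyridin-3-yl on an aromatic carbon. Within the data shown here, no measured step exchanges one pyridyl for another; the steps that bear on this change are a number 18.6 percentage points higher from compound 1 to compound 3 (beyond the scatter) and a number 16.4 percentage points higher from compound 2 to compound 3 (beyond the scatter), which show only that pyridin-3-yl gave a modest rise over phenyl and over benzyl. The data hold nothing that separates the two pyridyl groups, so a change in this assay no larger than the scatter is expected, in either direction. Compound 4 is therefore expected to give 30% in this assay, between 18% and 42%. The expected step is a number 3.2 percentage points lower from compound 3 to compound 4 (within the scatter).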

Compound 4, a percentage reported as activity, at one dose (the size of the read-out at that dose, not a potency): 32.6%
The estimate for compound 4 lay 2.6 percentage points below the measured number; measured number inside the range.
By their numbers in this assay, from the lowest: compounds 1 and 2 (each within the scatter of the next); then compounds 4 and 3 (each within the scatter of the next).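

The exchange of pyridin-3-yl for pyridin-4-yl on this aromatic carbon gives a number 0.6 percentage points lower from compound 3 to compound 4 (within the scatter), so in this assay the two pyridyl groups cannot be told apart. Pyridin-4-yl also stands clear of the other two groups, with a number 15.8 percentage points higher from compound 2 to compound 4 (beyond the scatter) and a number 18 percentage points higher from compound 1 to compound 4 (beyond the scatter), so among these four compounds the modest rise over benzyl and phenyl is not confined to pyridin-3-yl. No measurement shown here accounts for the gap between the pyridyl compounds and the other two.

The compounds shown leave open whether pyridin-2-yl would stand with the two pyridyl groups or with phenyl and benzyl. They also leave open what an amine or a carboxylic acid on the ring at this place would give in this assay.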